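A Ring Replaces the Amide on the Pyrrolidine Carbon

A few compounds are considered here, and "the series" means these few. Any claim that something is new, unique, unknown or untested is made for them only; others in the source may bear on it.

Three compounds share one core and differ only in the group attached to a saturated ring carbon. In an assay on cells for inhibition of Palmitoleoyl-protein carboxylesterase NOTUM variant C330S (Homo sapiens), read by fluorescence, with a stated time of 40 min (a higher number here means a weaker inhibitor, a lower number a stronger inhibitor), compound 1 `COCCNC(=O)C1CCN(c2ccc(Cl)c(C(F)(F)F)c2)C1` gives 3500 nM, the highest number of the three, so it is the weakest inhibitor shown. Compound 2 `O=C(Nc1ccccc1)C1CCN(c2ccc(Cl)c(C(F)(F)F)c2)C1` gives 1000 nM, and compound 3 `CN1CCN(C(=O)C2CCN(c3ccc(Cl)c(C(F)(F)F)c3)C2)CC1=O` gives 3100 nM.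

Compound 4 `O=c1[nH]nc(C2CCN(c3ccc(Cl)c(C(F)(F)F)c3)C2)o1` differs from compound 1 by a group of 6 heavy atoms (2 carbon, 2 nitrogen, 2 oxygen; one five-membered aromatic ring with 3 hetero atoms) in place of a group of 7 heavy atoms (4 carbon, 1 nitrogen, 2 oxygen; no ring), on a saturated ring carbon. This change removes the amide altogether, whereas the measured steps only vary what hangs on the amide: a 3.5-fold lower number from compound 1 to compound 2 (0.54 log units; beyond the scatter) and a 1.1-fold lower number from compound 1 to compound 3 (0.05 log units; within the scatter). Those two steps show that altering this end of the molecule can shift this assay by a modest amount or leave it unchanged, but neither step replaces the amide with an aromatic ring, so they bear only loosely on compound 4. The expected step is therefore uncertain in both size and direction, with a modest improvement taken as the central guess, a 2.9-fold lower number from compound 1 to compound 4 (0.46 log units; beyond the scatter).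

Compound 4 is estimated at 1200 nM, with a range from 250 nM to 6000 nM.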

Compound 4, half-maximal inhibitory concentration: 4200 nM
Compound 4: the middle estimate sits 3.5-fold (0.54 log units) below what was measured; low and high end bracket the measured number.
By their numbers in this assay, from the lowest: compound 2; then compounds 3, 1 and 4 (each within the scatter of the next).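

In this assay, among these compounds, the change reads as a 1.2-fold higher number from compound 1 to compound 4 (0.08 log units; within the scatter) and so adds something the earlier steps could not show. The amide itself, and not only what hangs on it, can leave this saturated ring carbon without a step beyond the scatter. A group with no ring and a five-membered aromatic ring with 3 hetero atoms thus give matching readings at this position, although they share little beyond their similar size in heavy atoms. No measurement is available that explains why these two groups read alike.

Among the compounds shown here, the only step here that goes beyond the scatter on the amide side is a 3.5-fold lower number from compound 1 to compound 2 (0.54 log units; beyond the scatter) and it comes from a phenyl group, so it remains open whether a phenyl group attached directly to the new ring would do the same. Also open, as far as these compounds go, is how a carboxylic acid or a simple amine would read on this ring carbon.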